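From a Piperidinylcarbonyl to a Dimethylamino Group

The compounds below may be only part of what the source reports. "The series", "measured", "known", "first", "only" and "open" are said of these compounds alone.

Measured compounds:
Compound 1 `CN1CCN(C(=O)c2cc(-c3ccccc3)sc2NC(N)=O)CC1`: "not determined" (no result reported)
Compound 2 `NC(=O)Nc1sc(-c2ccc(C(=O)N3CCCCC3)cc2)cc1C(=O)N[C@H]1CCCNC1`: 130 nM

Within the data shown here, in a functional assay on HT-29 cells (Homo sapiens) (a lower number here means that less compound is needed, a higher number that more compound is needed for the effect), compound 2 gives 130 nM, the only number in this set; compound 1 has no result. Compound 3 `CN(C)c1ccc(-c2cc(C(=O)N[C@H]3CCCNC3)c(NC(N)=O)s2)cc1` is the next compound. It differs from compound 2 in one place: dimethylamino in place of (piperidin-1-yl)carbonyl on an aromatic carbon. Among the measured compounds shown here, with no measured step to lean on, the size of the change is uncertain; a modest shift toward a higher value, possibly within the scatter, seems the most plausible outcome. Compound 3 is therefore expected to give about 220 nM, between 60 nM and 800 nM, a step of a 1.7-fold higher number from compound 2 to compound 3 (0.23 log units; within the scatter).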

Compound 3, half-maximal effective concentration: 90 nM
For compound 3 the middle estimate is 2.4-fold (0.39 log units) above the measured one; the measured number falls inside the stated range.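

In this assay, replacing (piperidin-1-yl)carbonyl with dimethylamino gives a 1.4-fold lower number from compound 2 to compound 3 (0.16 log units; within the scatter), so the two compounds cannot be told apart. At this position, then, the non-aromatic ring and the carbonyl can both be absent without a difference that stands out from the scatter, and a much smaller group serves as well here. Nothing available explains why the two groups read alike. From the compounds shown here alone, whether a carboxylic acid or a longer chain on this aromatic carbon would also read alike remains open.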